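Dimethoxy to Dihydroxy on the Benzylamine Arm

This account rests on a few compounds, and the source may have more. Where it says the series, first, only, none or still open, it means among the compounds named here.

Measured compounds:
Compound 1 `C=C1CC[C@@H]2[C@](C)(CNCc3ccc(OC)cc3)[C@H](O)CC[C@@]2(C)[C@@H]1/C=C/C1=CCOC1=O`; compound 2 `C=C1CC[C@@H]2[C@](C)(CNCc3cccc(OC)c3)[C@H](O)CC[C@@]2(C)[C@@H]1/C=C/C1=CCOC1=O`; compound 3 `C=C1CC[C@@H]2[C@](C)(CNCc3ccc(OC)c(OC)c3)[C@H](O)CC[C@@]2(C)[C@@H]1/C=C/C1=CCOC1=O`.

In a functional assay on BMMC cells (Mus musculus, strain C57BL/6) for inhibition, with stated times of 5 days and 48 h (on this read-out higher numbers stand for weaker inhibition and lower numbers for stronger inhibition), compound 1 gives 750 nM. In this assay compound 2 gives 780 nM, and a 1.0-fold higher number from compound 1 to compound 2 (0.02 log units; within the scatter). In this assay compound 3 gives 3740 nM, the highest of the three numbers; the steps of a 5.0-fold higher number from compound 1 to compound 3 (0.70 log units; beyond the scatter) and a 4.8-fold higher number from compound 2 to compound 3 (0.68 log units; beyond the scatter) both lie beyond the scatter. Compound 4 `C=C1CC[C@@H]2[C@](C)(CNCc3ccc(O)c(O)c3)[C@H](O)CC[C@@]2(C)[C@@H]1/C=C/C1=CCOC1=O` carries the change (3,4-dihydroxyphenyl in place of 3,4-dimethoxyphenyl on a saturated chain carbon bound to an amine nitrogen). Among the measured compounds shown here, no measured step exchanges methoxy for hydroxy, so none bears directly on this change; the measured steps concern only where methoxy sits and how many there are. Compound 4 is therefore expected to stay near compound 3, with a 1.3-fold lower number from compound 3 to compound 4 (0.13 log units; within the scatter) and an estimate of 2800 nM, ranging from 700 nM to 11000 nM.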

Compound 4, half-maximal inhibitory concentration: 9440 nM
Compound 4: the middle estimate sits 3.4-fold (0.53 log units) below what was measured, within the range that was stated.
By their numbers in this assay, from the lowest: compounds 1 and 2 (each within the scatter of the next); then compound 3; then compound 4.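

Going from the 3,4-dimethoxyphenyl to the 3,4-dihydroxyphenyl on a saturated chain carbon bound to an amine nitrogen gives, in this assay, a 2.5-fold higher number from compound 3 to compound 4 (0.40 log units; beyond the scatter) and is the first measured exchange of methoxy for hydroxy at this position. Measured against the compounds with a single methoxy, the gap grows to a 12-fold higher number from compound 2 to compound 4 (1.08 log units; beyond the scatter) and a 13-fold higher number from compound 1 to compound 4 (1.10 log units; beyond the scatter) and leaves compound 4 with the highest number of the four. Nothing on hand explains why this exchange moves the number upward.

From the compounds shown here alone, whether a single hydroxy on this ring would be enough for such a rise stays open. So does how a carboxylic acid or a fluorine on the same ring would read.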